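A few compounds are considered here, and "the series" means these few. Any claim that something is new, unique, unknown or untested is made for them only; others in the source may bear on it.

Compounds measured so far:
- compound 1, `CO[C@H]1O[C@H](CNC(=O)CN(Cc2ccccc2)C(C)=O)[C@@H](OS(=O)(=O)O)[C@H](OS(=O)(=O)O)[C@@H]1OS(=O)(=O)O`: 192000 nM
- compound 2, `CO[C@H]1O[C@H](CNC(=O)CN(C(C)=O)c2ccccc2)[C@@H](OS(=O)(=O)O)[C@H](OS(=O)(=O)O)[C@@H]1OS(=O)(=O)O`: 480000 nM
- compound 3, `CCN(CC(=O)NCCO[C@H]1O[C@H](COS(=O)(=O)O)[C@@H](OS(=O)(=O)O)[C@H](OS(=O)(=O)O)[C@@H]1OS(=O)(=O)O)C(=O)CCCCCCCCCOS(=O)(=O)O`: 157000 nM

The account concerns an assay on isolated protein for binding affinity to fibroblast growth factor 2 (Homo sapiens), read by surface plasmon resonance; a lower number here means tighter binding, a higher number weaker binding. Compound 2 stands with the highest number of the three: compound 1 sits nearer to it, and compound 3 sits furthest, with the lower number. Among the compounds with values here, the one single-point step among the measured compounds, phenyl in place of benzyl on an amide-type nitrogen, gave a 2.5-fold higher number from compound 1 to compound 2 (0.40 log units; beyond the scatter).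

Compound 4, `CCN(CC(=O)NC[C@H]1O[C@H](OC)[C@@H](OS(=O)(=O)O)[C@@H](OS(=O)(=O)O)[C@@H]1OS(=O)(=O)O)C(=O)CCCCC(=O)O`, is not yet measured. It differs from compound 2 in one place: ((4-carboxybutyl)carbonyl)(ethyl)amino in place of acetyl(phenyl)amino on a saturated chain carbon bound to a carbonyl carbon. Within the data shown here, no measured step matches this change. Compound 3, which carries an ethyl on its amide-type nitrogen and a long acyl chain, gives 157000 nM, but it differs from compound 2 in several places at once, so only the two values themselves can be set side by side. Among the measured compounds shown here, the one known step, from benzyl to phenyl, is modest, and it concerns a ring that compound 4 no longer carries. On these grounds compound 4 is expected to move back toward the numbers of compound 1 and compound 3, a step of a 2.2-fold lower number from compound 2 to compound 4 (0.34 log units; beyond the scatter), with the wide range such a sparse set demands. The estimate for compound 4 in this assay is 220000 nM, between 80000 nM and 600000 nM.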

Compound 4, dissociation constant: 480000 nM
Estimate against measurement, compound 4: 2.2-fold (0.34 log units) below; low and high end bracket the measured number.
By their numbers in this assay, from the lowest: compounds 3 and 1 (each within the scatter of the next); then compounds 2 and 4 (each within the scatter of the next).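

In this assay, the step of no change at the digits printed from compound 2 to compound 4 (within the scatter) shows that at this position, on a saturated chain carbon bound to a carbonyl carbon, the six-membered aromatic ring of acetyl(phenyl)amino can give way to the ring-free ((4-carboxybutyl)carbonyl)(ethyl)amino without a change beyond the scatter. The earlier compounds shown here had tested this position only with aromatic rings, and the new step of a 2.5-fold higher number from compound 1 to compound 4 (0.40 log units; beyond the scatter) adds that compound 1, with acetyl(benzyl)amino, keeps the lower number against the ring-free group as well as against acetyl(phenyl)amino. The data offer no measured explanation for either step.

The change from compound 2 to compound 4 replaces the phenyl with an ethyl and the acetyl with the longer acyl chain carrying a carboxylic acid in a single step, so the share of each part cannot be separated. Also open, on these data alone, is whether an amine or a primary amide in place of that carboxylic acid, or a longer chain carrying it, would give a number in this assay that differs from those of compound 2 and compound 4.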